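From 4-cyanophenyl to 4-fluorophenyl: working notes on the series

This account rests on a few compounds, and the source may have more. Where it says the series, first, only, none or still open, it means among the compounds named here.

In a functional assay on MCF7 cells (Homo sapiens) for cytotoxicity, read by MTT assay, with a stated time of 72 h (a higher number here means a weaker inhibitor, a lower number a stronger inhibitor), compound 1 (`CNC(=O)c1cc(Oc2ccc(C(=O)/C=C/c3ccc(Cl)c(Cl)c3)cc2)ccn1`) gives 13200 nM. Compound 2 (`CNC(=O)c1cc(Oc2ccc(C(=O)/C=C/c3ccc(C#N)cc3)cc2)ccn1`) stands at 9520 nM, within the scatter of compound 1, so the two numbers do not separate these compounds.

The next structure is compound 3 (`CNC(=O)c1cc(Oc2ccc(C(=O)/C=C/c3ccc(F)cc3)cc2)ccn1`), which has fluoro in place of cyano on an aromatic carbon, para to a large group: fluoro in place of cyano on an aromatic carbon. The same difference, cut one bond further out, reads 4-cyanophenyl to 4-fluorophenyl.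

For the measured compounds named here, only one measured step bears on this change: a 1.4-fold lower number from compound 1 to compound 2 (0.14 log units; within the scatter). It swaps the aryl group at the same place and stays within the scatter. Going by the values given here, it is a single step, and no measured compound carries fluoro, so the support is thin. On that basis, no step beyond the scatter is expected in this assay, and no direction is favoured with any confidence.

The expected step is a 1.2-fold higher number from compound 2 to compound 3 (0.06 log units; within the scatter). The estimate for compound 3 is 11000 nM, with an expected range of 5500 nM to 22000 nM.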

Compound 3, half-maximal inhibitory concentration: 28500 nM
For compound 3 the middle estimate is 2.6-fold (0.41 log units) below the measured one, outside the stated range (above it).
By their numbers in this assay, from the lowest: compounds 2 and 1 (each within the scatter of the next); then compound 3.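

In this assay, this position does separate compounds: a 3.0-fold higher number from compound 2 to compound 3 (0.48 log units; beyond the scatter) stands beyond the scatter, with fluoro in place of cyano on an aromatic carbon, para to a large group. The 4-fluorophenyl group also parts from the 3,4-dichlorophenyl group, as a 2.2-fold higher number from compound 1 to compound 3 (0.33 log units; beyond the scatter) is likewise beyond the scatter, so compound 3 has the highest number of the three, while compound 1 and compound 2 remain within the scatter of each other. No measurement at hand offers an explanation for this difference.

For the compounds shown here, with only three aryl groups compared, the series gives no trend at this position, and an amine, a methoxy group or a carboxylic acid in the place of fluoro could fall on either side of these numbers. Also open, from the compounds shown here alone, is whether the step from cyano to fluoro keeps its size and direction in other cell lines, or with a longer chain in place of the methyl on the amide of the shared core.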